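Dialkylamino chain variation across two cores in Raji cells

The source may hold more compounds than are shown below. What is called first, only, known or untested is meant among the compounds shown, and "the series" means these compounds.

Measured so far:
compound 1 `CN(C)CCCCn1c(N)c(-c2nc3ccccc3o2)c2nc(C#N)c(C#N)nc21` — 9200 nM
compound 2 `CCN(CC)CCCCn1c(N)c(-c2nc3ccccc3o2)c2nc(C#N)c(C#N)nc21` — 2610 nM
compound 3 `CN(C)CCn1c(N)c(-c2nc3ccccc3n2C)c2nc(C#N)c(C#N)nc21` — 46500 nM

In a functional assay on Raji cells (Homo sapiens) for antiproliferative activity, read by MTT assay, with a stated time of 48 h (on this read-out higher numbers stand for weaker inhibition and lower numbers for stronger inhibition), compound 1 gives 9200 nM. Compound 2 gives 2610 nM. The change diethylamino in place of dimethylamino on a saturated chain carbon, four bonds along the chain from an aromatic nitrogen produced a 3.5-fold lower number from compound 1 to compound 2 (0.55 log units; beyond the scatter). Compound 3 gives 46500 nM, the highest number of the three. The difference between the core of compound 1 and the core of compound 3 is not broken down here.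

Compound 4 `CCN(CC)CCn1c(N)c(-c2nc3ccccc3n2C)c2nc(C#N)c(C#N)nc21` is not yet measured. It differs from compound 3 by diethylamino in place of dimethylamino on a saturated chain carbon, two bonds along the chain from an aromatic nitrogen; this is the same kind of change as that from compound 1 to compound 2, but it sits two bonds along the chain from the aromatic nitrogen rather than four. A step of similar size is expected, a 3.1-fold lower number from compound 3 to compound 4 (0.49 log units; beyond the scatter), resting on compound 1 to compound 2 giving a 3.5-fold lower number from compound 1 to compound 2 (0.55 log units; beyond the scatter). Compound 4 is therefore estimated at 15000 nM, between 6000 nM and 40000 nM.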

Compound 4, half-maximal inhibitory concentration: 2080 nM
Compound 4: middle estimate off by 7.2-fold (0.86 log units), on the high side; measured number outside the range, below it.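

In this assay, diethylamino in place of dimethylamino gives a 22-fold lower number from compound 3 to compound 4 (1.35 log units; beyond the scatter), so the direction of the step carries over from the earlier pair but its size does not: the same change on two cores in this assay, a 3.5-fold lower number (0.55 log units; beyond the scatter) from compound 1 to compound 2 and a 22-fold lower number (1.35 log units; beyond the scatter) from compound 3 to compound 4, 6.3-fold (0.80 log units) apart, beyond the scatter of two such steps.

The two pairs differ in core and also in where the amine sits, two or four bonds along the chain from an aromatic nitrogen, so these compounds cannot show which difference goes with the larger step. Two pairs also give no rule for any further core.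

Still open, from the compounds shown here alone, is how the same change behaves with the 2-(diethylamino)ethyl and 2-(dimethylamino)ethyl chains on the core of compound 1, and with the longer chain on the core of compound 3. Cyclic amines such as piperidine or morpholine also remain open.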